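Branched acyl chain on the bicyclic amide series

The source may hold more compounds than are shown below. What is called first, only, known or untested is meant among the compounds shown, and "the series" means these compounds.

Measured compounds:
Compound 1, `CC(=O)N1CC2CC(C1)N2`, gives 100% in an assay on CHO cells for agonist activity at Neuronal acetylcholine receptor; alpha3/alpha6/beta2/beta3 (Homo sapiens), read by FLIPR and calcium flux; on this read-out higher numbers stand for larger maximal responses and lower numbers for smaller maximal responses.
Compound 2, `CCC(=O)N1CC2CC(C1)N2`, gives 120%.
Compound 3, `CCCC(=O)N1CC2CC(C1)N2`, gives 92%.

Compound 3 stands lowest of the three in this assay: its gap to compound 1 lies within the scatter, while compound 2 sits clearly higher, the step being a number 28 percentage points lower from compound 2 to compound 3 (beyond the scatter).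

Compound 4, `CC(C)C(=O)N1CC2CC(C1)N2`, differs from compound 3 by isopropyl in place of propyl on a carbonyl carbon. Within the data shown here, two measured steps bear on this. Adding a methyl on the chain carbon bound to the carbonyl gave a number 20 percentage points higher from compound 1 to compound 2 (beyond the scatter), whereas adding a methyl two bonds along the chain gave a number 28 percentage points lower from compound 2 to compound 3 (beyond the scatter). Compound 4 keeps the first kind of branching and drops the second, so a modest rise in this assay is expected, roughly toward the level of compound 2. The step expected is a number 18 percentage points higher from compound 3 to compound 4 (beyond the scatter). Compound 4 is estimated at 110%, with a range from 88% to 132%.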

Compound 4, largest response reached (Emax), in percent of the reference or control that the assay uses: 45%
Compound 4: middle estimate off by 65 percentage points, on the high side; the whole stated range lies above it.
By their numbers in this assay, from the lowest: compound 4; then compounds 3 and 1 (each within the scatter of the next); then compound 2.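

In this assay, the step of a number 47 percentage points lower from compound 3 to compound 4 (beyond the scatter) shows that how the carbons are joined at this position, and not how many there are, separates propyl from isopropyl. The second methyl on the saturated chain carbon bound to the carbonyl carbon does not extend the rise seen with the first, since a number 75 percentage points lower from compound 2 to compound 4 (beyond the scatter) reverses it, and isopropyl in place of methyl likewise gives a number 55 percentage points lower from compound 1 to compound 4 (beyond the scatter) on the same core, so the effect of a methyl at this carbon depends on what else that carbon carries. Nothing measured here accounts for this reversal.

Going by these compounds, whether a tert-butyl or cyclopropyl group on the carbonyl carbon would track isopropyl remains open. Also open, on these data alone, is whether a longer straight chain such as butyl would stay level with propyl.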